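Spiro-core amide series: swapping the hydroxymethylpiperidine tail

A few compounds are considered here, and "the series" means these few. Any claim that something is new, unique, unknown or untested is made for them only; others in the source may bear on it.

The shared core carries a tail amide that varies across the set. For compound 1 `CC(C)(C)OC(=O)NCCCCNC(=O)CN1CN(c2ccccc2)C2(CCN(C(=O)c3ccc(C(C)(C)C)cc3)CC2)C1=O` the result in an assay on HEK293 cells for displacement of a labelled ligand from NPC1-like intracellular cholesterol transporter 1 (Homo sapiens) (a lower number here means a stronger inhibitor, a higher number a weaker inhibitor), is "not determined" (no result reported). Among the measured compounds shown here, compound 2 `CC(C)(C)c1ccc(C(=O)N2CCC3(CC2)C(=O)N(CC(=O)NCCCCCNS(C)(=O)=O)CN3c2ccccc2)cc1` gives 5500 nM in this assay, and compound 3 `CC(C)(C)c1ccc(C(=O)N2CCC3(CC2)C(=O)N(CC(=O)N2CCCCC2CO)CN3c2ccccc2)cc1` gives 11800 nM, the higher of the two numbers; the step of a 2.1-fold higher number from compound 2 to compound 3 (0.33 log units; beyond the scatter) is the only measured change bearing on the tail. Compound 4 `CC(C)(C)c1ccc(C(=O)N2CCC3(CC2)C(=O)N(CC(=O)NCCCCO)CN3c2ccccc2)cc1` differs from compound 3 by (4-hydroxybutyl)amino in place of 2-(hydroxymethyl)piperidin-1-yl on a carbonyl carbon, returning from a ring amide to an open-chain secondary amide, as in compound 2. On that analogy a step of comparable size back toward a lower number is expected, a 1.7-fold lower number from compound 3 to compound 4 (0.23 log units; within the scatter), though one pair is thin ground. Compound 4 is therefore estimated at 7000 nM in this assay, with a range of 3500 nM to 14000 nM.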

Compound 4, half-maximal inhibitory concentration: 19200 nM
Compound 4: the middle estimate sits 2.7-fold (0.44 log units) below what was measured; the measured number lies above the stated range.
By their numbers in this assay, from the lowest: compound 2; then compounds 3 and 4 (each within the scatter of the next).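

Replacing the ring amide with the open-chain (4-hydroxybutyl)amino tail gives no separable change, with a 1.6-fold higher number from compound 3 to compound 4 (0.21 log units; within the scatter). The open-chain secondary amide therefore does not by itself bring the number back to that of compound 2, whereas the chain end does matter, with a 3.5-fold higher number from compound 2 to compound 4 (0.54 log units; beyond the scatter). No available evidence accounts for either step.

As far as these compounds go, whether a terminal amine or carboxylic acid would give a lower number than the methanesulfonamido end remains open. So does the effect of a longer chain carrying that end.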